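Removing the methyl from the phenol ether: compound 3 to compound 4

The source may report more compounds than this note shows. Statements on the series, on what has been measured and on what is new or still open speak of the compounds shown alone.

Measured in a functional assay on NCI-H322M cells (Homo sapiens) for inhibition, read by sulforhodamine B assay, with a stated time of 48 h; on this read-out lower numbers stand for stronger inhibition of growth and higher numbers for weaker inhibition of growth:
compound 1 `COc1cc(C)cc(-c2c(-c3ccnc(-c4ccc(C(C)=O)cc4)c3)cnn2CC#N)c1` gives > 100000 nM, which is a limit of the assay and not a number.
compound 2 `Cc1cc(O)cc(-c2nn(CC#N)cc2-c2ccnc(-c3ccc(Oc4ccccc4)cc3)c2)c1` gives 19200 nM.
compound 3 `COc1cc(C)cc(-c2nn(CC#N)cc2-c2ccnc(-c3ccc(N(C)C)cc3)c2)c1` gives > 1000 nM, again a limit of the assay rather than a number.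

Compound 3 therefore has no exact place on the scale; it sits at the limit where one of the three results lies (the limit of > 1000 nM in this assay, at which 1 of the 3 values shown sits), while compound 1 sits at the other limit (the limit of > 100000 nM in this assay, at which 1 of the 3 values shown sits). Compound 2 is the only one of the three with a true number.

Compound 4 `Cc1cc(O)cc(-c2nn(CC#N)cc2-c2ccnc(-c3ccc(N(C)C)cc3)c2)c1` differs from compound 3 in a single spot: hydrogen in place of methyl on an oxygen on an aromatic ring, turning methoxy into hydroxy and 3-methoxy-5-methylphenyl into 3-hydroxy-5-methylphenyl. Among the measured compounds shown here, no measured pair shows this exact change. Compound 2 carries the same hydroxy group with a different substituent on its far ring and gives 19200 nM, so a true number seems more likely for compound 4 as well. Because compound 3 gives > 1000 nM, only a rough anchor exists, and the expected step is a step that the limit leaves unreadable from compound 3 to compound 4. Compound 4 is estimated at 15000 nM, in the range 3000 nM to 80000 nM.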

Compound 4, concentration for total growth inhibition: 59800 nM
The estimate for compound 4 lay 4.0-fold (0.60 log units) below the measured number; the measured number falls inside the stated range.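

In this assay compound 4 gives a true number, 59800 nM, so the 3-hydroxy-5-methylphenyl group now has exact values with two different substituents. With that group held fixed, dimethylamino in place of phenoxy on an aromatic carbon gives a 3.1-fold higher number from compound 2 to compound 4 (0.49 log units; beyond the scatter), which means somewhat weaker inhibition of growth and is the first step among these compounds that can be read. The change from methoxy to hydroxy itself cannot be read, because compound 3 stands only at a limit of the assay: the limit of > 1000 nM in this assay, at which 1 of the 4 values shown sits.

On these data alone, whether hydrogen in place of methyl on that oxygen strengthens or weakens inhibition of growth therefore stays open. Also open, as far as these compounds go, is how an ethyl group on that oxygen, or a carboxylic acid in place of dimethylamino, would change the number.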